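Piperazine nitrogen substituent in the isoxazole-aryl ether series

A few compounds are considered here, and "the series" means these few. Any claim that something is new, unique, unknown or untested is made for them only; others in the source may bear on it.

Measured compounds:
- compound 1 `Cc1ccccc1COc1ccc(-c2cc(CN3CCN(Cc4ccc(C(F)(F)F)cc4)CC3)no2)cc1`: 3700 nM
- compound 2 `N#Cc1cccc(COc2ccc(-c3cc(CN4CCN(c5ccc(C(F)(F)F)cc5)CC4)no3)cc2)c1`: 2000 nM

In a functional assay on MCF7 cells (Homo sapiens) for antiproliferative activity, read by sulforhodamine B assay, with a stated time of 72 h (a lower number here means a stronger inhibitor, a higher number a weaker inhibitor), compound 2 gives 2000 nM, while compound 1 gives 3700 nM; the gap between the two is within the scatter, so they are indistinguishable on this assay. Compound 2 is the reference for the next step.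

Compound 3 `N#Cc1cccc(COc2ccc(-c3cc(CN4CCN(CC5CCCO5)CC4)no3)cc2)c1` is not yet measured. It differs from compound 2 in one place: (oxolan-2-yl)methyl in place of 4-(trifluoromethyl)phenyl on an amine nitrogen in a ring. Within the data shown here, no measured pair shows a step of this kind, so the size of the change is open. The two measured compounds share an aromatic ring, direct or through one carbon, on that ring nitrogen; compound 3 carries a saturated group there instead. The expectation for compound 3 is a modest weakening, with wide uncertainty, as a 2.5-fold higher number from compound 2 to compound 3 (0.40 log units; beyond the scatter). Compound 3 is estimated at 5000 nM in this assay, in the range 1500 nM to 15000 nM.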

Compound 3, half-maximal inhibitory concentration: 8400 nM
Beside the measured number, compound 3's estimate is 1.7-fold (0.23 log units) below it, and the stated range covers the measured number.
By their numbers in this assay, from the lowest: compounds 2 and 1 (each within the scatter of the next); then compound 3.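

Among these compounds, this is the first one-place step: in this assay, (oxolan-2-yl)methyl in place of 4-(trifluoromethyl)phenyl on the amine nitrogen in a ring gives a 4.2-fold higher number from compound 2 to compound 3 (0.62 log units; beyond the scatter), a modest weakening. The position therefore responds to the group it carries, yet the saturated group still leaves a measurable value, so an aromatic ring on that nitrogen is not needed for a reading in this assay. Nothing in the data available assigns this step to any particular feature of either group.

The step changes the ring type, the heavy-atom count and the hydrogen-bond acceptor count at once, so these cannot be told apart. Open, as far as these compounds go, is whether an unsubstituted phenyl or a cyclopentylmethyl group, which has no ring oxygen, would fall nearer compound 2 or compound 3.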